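The source may hold more compounds than are shown below. What is called first, only, known or untested is meant among the compounds shown, and "the series" means these compounds.

Compound 1, `CC(C)(C)CC(=O)N1CCC(CCCC(=O)c2ncco2)CC1`, gives 90 nM in an assay on isolated protein for inhibition of Fatty-acid amide hydrolase 1 (Homo sapiens); a lower number here means a stronger inhibitor, a higher number a weaker inhibitor.
Compound 2, `Cc1cccc(CN2CCC(CCCC(=O)c3ncco3)CC2)c1`, gives 90 nM in this assay.
Compound 3, `Cc1ccc(CN2CCC(CCCC(=O)c3ncco3)CC2)cc1`, gives 400 nM in this assay.

Compound 3 stands at the highest of the three numbers, set apart from the other two by a 4.4-fold higher number from compound 1 to compound 3 (0.65 log units; beyond the scatter) and by a 4.4-fold higher number from compound 2 to compound 3 (0.65 log units; beyond the scatter), both beyond the scatter. Compound 4, `CC(C)c1ccc(CN2CCC(CCCC(=O)c3ncco3)CC2)cc1`, differs from compound 3 by isopropyl in place of methyl on an aromatic carbon. Among the compounds with values here, no measured step alters the same place: no change at the digits printed from compound 1 to compound 2 (within the scatter) and a 4.4-fold higher number from compound 1 to compound 3 (0.65 log units; beyond the scatter) exchange the whole group on the ring nitrogen, and a 4.4-fold higher number from compound 2 to compound 3 (0.65 log units; beyond the scatter) moves the methyl from one aromatic carbon to another. None enlarges a group at a fixed aromatic carbon, so the measured steps give only an indirect guide. With the ring nitrogen substituent and the rest of the core unchanged, the step is expected to stay within the scatter or to raise the number modestly, so that a 1.3-fold higher number from compound 3 to compound 4 (0.10 log units; within the scatter) is the estimated outcome. For compound 4 the expected value in this assay is 500 nM, with an estimated range from 150 nM to 1600 nM.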

Compound 4, half-maximal inhibitory concentration: 3.6 nM
The estimate for compound 4 lay 140-fold (2.14 log units) above the measured number, and the stated range ends above it.
By their numbers in this assay, from the lowest: compound 4; then compounds 1 and 2 (each within the scatter of the next); then compound 3.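

Isopropyl in place of methyl on this aromatic carbon, para to a large group, gives a 110-fold lower number from compound 3 to compound 4 (2.05 log units; beyond the scatter) in this assay with the rest of the molecule held fixed. Within the data shown here, this is the first step to change only the size of the group at a fixed aromatic carbon, and it is far larger than any step among the first three compounds, so compound 4 at 3.6 nM now has the lowest number of the four. No measurement shown here accounts for the size of this step.

The compounds shown leave open whether the gain continues with a tert-butyl or cyclopropyl group at this carbon, or already appears with an ethyl group. They also leave open whether an isopropyl group would have a similar effect on the aromatic carbon that carries the methyl in compound 2.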